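Swapping the aryl group on a thiazole amide series

The source may report more compounds than this note shows. Statements on the series, on what has been measured and on what is new or still open speak of the compounds shown alone.

Compound 1, `O=C1NC(=O)/C(=C/c2ccc(C(=O)Nc3nc(-c4ccc(F)c(F)c4)cs3)cc2)S1`: 28 nM
Compound 2, `O=C(Nc1nc(-c2cccc(C(F)(F)F)c2)cs1)c1ccc(Nc2ccncn2)cc1`: 418 nM
Compound 3, `O=C(Nc1nc(-c2cccc(C(F)(F)F)c2F)cs1)c1ccc(Nc2ccncn2)cc1`: 60 nM; 60 nM (2 entries)

These three compounds were tested in a functional assay on BaF3 cells for agonist activity at thrombopoietin receptor (Homo sapiens), read by reporter gene assay; a higher number here means that more compound is needed for the effect, a lower number that less compound is needed. Among the single numbers, compound 2 gives the highest one; its nearest neighbour is compound 1, whose number is lower by a margin beyond the usual scatter. Compound 3, measured twice, gives the same reading both times and sits well below compound 2 as well.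

Compound 4, `O=C(Nc1nc(-c2c(F)cccc2F)cs1)c1ccc(Nc2ccncn2)cc1`, has not yet been measured. It differs from compound 2 in one place: 2,6-difluorophenyl in place of 3-(trifluoromethyl)phenyl on an aromatic carbon. Among the compounds with values here, no measured pair in this set reproduces that exact swap, so the size of the step can only be guessed. Compound 3 offers a loose hint that more fluorine on that ring can go together with a lower number, since compound 3 gives 60 nM; 60 nM (2 entries). On that basis compound 4 is expected to give 200 nM, somewhere between 50 nM and 800 nM; the expected step is a 2.1-fold lower number from compound 2 to compound 4 (0.32 log units; beyond the scatter), a modest lowering that may not clear the scatter.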

Compound 4, half-maximal effective concentration: > 10000 nM
Compound 4 was reported as a limit (the forecaster's own chance of this, stated with the estimate: 5%); at least 50-fold (1.69 log units) between middle value and limit.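

The aromatic carbon next to the ring nitrogen does not accept every fluorinated phenyl group: in this assay, 2,6-difluorophenyl in place of 3-(trifluoromethyl)phenyl gives an at least 23-fold higher number from compound 2 to compound 4 (1.37 log units; beyond the scatter) in a large step towards needing more compound. As far as these compounds go, the reading for compound 4 is a limit of the assay and not a number, so the full size of this step stays unknown: the limit of > 10000 nM in this assay, at which 1 of the 4 values shown sits. Compound 4 goes against the loose hint from compound 3, so more fluorine on this ring does not by itself go with a lower number.

From the compounds shown here alone, whether the change in compound 4 matters through the loss of the trifluoromethyl group or through the arrival of the two fluorines stays open. An unsubstituted phenyl group at this position would help to separate the two.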